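This account rests on a few compounds, and the source may have more. Where it says the series, first, only, none or still open, it means among the compounds named here.

Compound 1 `CN(C)c1nccc2c1ncn2[C@H]1C[C@H](O)[C@@H](CO)O1` gives 0% in a functional assay (Homo sapiens) for inhibition of Nucleic Acid, tested at 100 uM (a lower number here means less inhibition, a higher number more inhibition at the concentration tested (going by the name of the read-out)), and compound 2 `OC[C@H]1O[C@@H](n2cnc3c(SCc4ccccc4)nccc32)C[C@@H]1O` gives 18%. Among the compounds with values here, the one measured step, a number 18 percentage points higher from compound 1 to compound 2 (beyond the scatter), places compound 2 as the higher of the two numbers, beyond the scatter. Compound 3 `OC[C@H]1O[C@@H](n2cnc3c(S)nccc32)C[C@@H]1O` differs from compound 2 by hydrogen in place of benzyl on a sulfur. Within the data shown here, no measured step removes a benzyl from sulfur; the single step at hand shows the benzylsulfanyl compound above the dimethylamino compound, so the inhibition of compound 2 may depend on the benzyl. Among the measured compounds shown here, a downward step is therefore expected, a number 13 percentage points lower from compound 2 to compound 3 (beyond the scatter), of a size no larger than the one step already seen. Compound 3 is estimated at 5%, with a range from 0% to 18%.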

Compound 3, a percentage reported as inhibition, at one concentration (the size of the read-out at that concentration, not a potency): 10%
Estimate against measurement, compound 3: 5 percentage points below, and the stated range covers the measured number.
By their numbers in this assay, from the lowest: compounds 1, 3 and 2 (each within the scatter of the next, the first and the last beyond it).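

Hydrogen in place of benzyl on a sulfur gives a number 8 percentage points lower from compound 2 to compound 3 (within the scatter) in this assay and so does not show that the benzyl is needed for the inhibition seen with compound 2. Sulfanyl in place of dimethylamino on an aromatic carbon gives a number 10 percentage points higher from compound 1 to compound 3 (within the scatter) and so leaves compound 3 not separated from either neighbour. No evidence on the cause of these numbers is at hand. Going by these compounds, whether a methyl, a longer chain or an amine on that sulfur would give a step beyond the scatter remains open.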